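Propyl to hexyl in a limit-bound series

A few compounds are considered here, and "the series" means these few. Any claim that something is new, unique, unknown or untested is made for them only; others in the source may bear on it.

- compound 1 `CCCOP(=O)(O)OCCSC(=S)N1CCCCC1`: > 100000 nM, a limit
- compound 2 `CCCOP(=O)(O)OCCSC(=S)N1CCCC1`: > 100000 nM, a limit

In a functional assay on DU-145 cells (Homo sapiens) for inhibition, read by MTT assay, with stated times of 18 h and 4 h (on this read-out lower numbers stand for stronger inhibition and higher numbers for weaker inhibition), compound 1 stands at > 100000 nM, which is a limit and not a number. Compound 2 gives > 100000 nM, also a limit. The evidence so far is the limit of > 100000 nM in this assay, at which 2 of the 2 values shown sit.

Compound 3 `CCCCCCOP(=O)(O)OCCSC(=S)N1CCCCC1` differs from compound 1 by propyl in place of hydrogen on a saturated chain carbon, three bonds along the chain from an oxygen on an unsaturated carbon; the same difference reads propyl to hexyl.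

Among the measured compounds shown here, the only measured step, a step that the two limits leave unreadable from compound 1 to compound 2, lies at another place in the molecule and gives no size to carry over. The expected change in this assay is a number no higher from compound 1 to compound 3 (the limit leaves the size open), with no direction fixed by the data. The estimate for compound 3 is 100000 nM, with an expected range of 30000 nM to 300000 nM.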

Compound 3, half-maximal inhibitory concentration: > 100000 nM
Compound 3 gave a limit, no number; the forecaster's own chance of this, stated with the estimate: 65%; the middle value sits exactly at the limit.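

Among the compounds shown here, compound 3 and compound 1 both sit at a limit in this assay, so no step between them can be read. The compounds shown leave open whether any change to the shared core yields a number rather than a limit: the limit of > 100000 nM in this assay, at which 3 of the 3 values shown sit.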